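Swapping the pyridine arm of compound 1 for a dimethylaminophenyl

A few compounds are considered here, and "the series" means these few. Any claim that something is new, unique, unknown or untested is made for them only; others in the source may bear on it.

Among the compounds with values here, compound 1 `COc1ccc(S(=O)(=O)N2CCc3cccc(-c4cccnc4)c32)cc1` is one of three compounds measured in a functional assay on KB-VIN10 cells (Homo sapiens) for inhibition, with a stated time of 72 h (a lower number here means a stronger inhibitor, a higher number a weaker inhibitor), where compound 1 gives 84.5 nM. That places compound 1 second highest of the three numbers. Its closest neighbour is compound 3 `COc1ccc(S(=O)(=O)n2ccc3cccc(-c4ccc(F)cc4)c32)cc1`, which in this assay gives 202 nM, and the furthest is compound 2 `COc1ccc(S(=O)(=O)N2CCc3cccc(-c4ccc(C#N)cc4)c32)cc1`, which gives 29.2 nM.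

Compound 4 `COc1ccc(S(=O)(=O)N2CCc3cccc(-c4ccc(N(C)C)cc4)c32)cc1` has not yet been measured. It differs from compound 1 in one place: 4-(dimethylamino)phenyl in place of pyridin-3-yl on an aromatic carbon. Within the data shown here, only one measured step bears on this change. Compound 2 also carries an aromatic ring of carbon only in place of the pyridin-3-yl of compound 1, and the step there is a 2.9-fold lower number from compound 1 to compound 2 (0.46 log units; beyond the scatter). Among the measured compounds shown here, the group that enters in compound 4 is a different one, and no measured pair shows a 4-(dimethylamino)phenyl, so the step from compound 1 to compound 4 is expected to be at most modest, more likely toward a lower number than a higher one. The expected step is a 1.7-fold lower number from compound 1 to compound 4 (0.23 log units; within the scatter). Compound 4 is therefore expected to give about 50 nM in this assay, with a range from 15 nM to 170 nM.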

Compound 4, half-maximal inhibitory concentration: 553 nM
The estimate for compound 4 lay 11-fold (1.04 log units) below the measured number; the measured number lies above the stated range.
By their numbers in this assay, from the lowest: compound 2; then compound 1; then compound 3; then compound 4.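

In this assay, the change from pyridin-3-yl to 4-(dimethylamino)phenyl gives a 6.5-fold higher number from compound 1 to compound 4 (0.82 log units; beyond the scatter) and so produces a weaker inhibitor, which shows that an aromatic ring of carbon only at this place does not by itself bring a stronger one. What that ring carries matters a great deal: dimethylamino in place of cyano gives a 19-fold higher number from compound 2 to compound 4 (1.28 log units; beyond the scatter) in the same assay, the largest step among these compounds, even though the rest of the molecule stays the same. No measurement available here explains why these two groups differ so widely.

The compounds shown leave open whether the weaker inhibition belongs to dimethylamino in particular or extends to other groups on this ring. A plain phenyl ring would give a baseline for both the cyano and the dimethylamino compounds, while a ring carrying a primary amine or a carboxylic acid would show how far the trend holds for other nitrogen-containing or oxygen-containing groups.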